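From 3-fluorophenyl to 4-(methylsulfonyl)phenyl on the shared core

The source may hold more compounds than are shown below. What is called first, only, known or untested is meant among the compounds shown, and "the series" means these compounds.

In an ADME assay (liver) for metabolic stability, with Liver microsome (Rattus norvegicus) as the target, using microsomes and NADPH, with a stated time of 30 min, tested at 1 uM (on this read-out lower numbers stand for slow clearance and higher numbers for fast clearance), compound 3 (`Nc1ccc(S(=O)(=O)N2CCN(c3ncc(C(O)(C(F)(F)F)C(F)(F)F)cc3-c3cccc(F)c3)CC2)cn1`) gives 52 mL.min-1.g-1, the highest number in the series. Compound 2 (`CC(C)(O)C#Cc1cc(C(O)(C(F)(F)F)C(F)(F)F)cnc1N1CCN(S(=O)(=O)c2ccc(N)nc2)CC1`) gives 16 mL.min-1.g-1. Compound 1 (`COc1cc(C(O)(C(F)(F)F)C(F)(F)F)cnc1N1CCN(S(=O)(=O)c2ccc(N)nc2)CC1`) gives < 14 mL.min-1.g-1, which is a limit of the assay and not a number. Compound 4 (`CS(=O)(=O)c1ccc(-c2cc(C(O)(C(F)(F)F)C(F)(F)F)cnc2N2CCN(S(=O)(=O)c3ccc(N)nc3)CC2)cc1`) is still unmeasured and differs from compound 3 as follows: 4-(methylsulfonyl)phenyl in place of 3-fluorophenyl on an aromatic carbon. In words, this is 4-(methylsulfonyl)phenyl in place of 3-fluorophenyl on an aromatic carbon. The nearest guides are the steps that introduce 3-fluorophenyl: a 3.3-fold higher number from compound 2 to compound 3 (0.51 log units; beyond the scatter) and an at least 3.7-fold higher number from compound 1 to compound 3 (0.56 log units; beyond the scatter). The remaining step, an at least 1.1-fold higher number from compound 1 to compound 2 (0.05 log units; that floor lies within the scatter), says little. Within the data shown here, no measured step exchanges one aromatic ring for another, so these sizes transfer only loosely. Compound 4 keeps the six-membered aromatic ring of carbon only, so the value of compound 3, 52 mL.min-1.g-1, remains the main anchor. The expected change is a 1.6-fold lower number from compound 3 to compound 4 (0.21 log units; within the scatter), towards a lower number but not expected to pass beyond the scatter. For compound 4 the estimated value is 32 mL.min-1.g-1, with an expected range from 15 mL.min-1.g-1 to 65 mL.min-1.g-1.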

Compound 4, intrinsic clearance in microsomes: 103 mL.min-1.g-1
Compound 4: middle estimate off by 3.2-fold (0.51 log units), on the low side; the whole stated range lies below it.
By their numbers in this assay, from the lowest: compound 2; then compounds 3 and 4 (each within the scatter of the next). At a limit, below all of these: compound 1.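

Exchanging one six-membered aromatic ring of carbon only for another at this position, ortho to a large group, is new to the series, and in this assay the result is a 2.0-fold higher number from compound 3 to compound 4 (0.30 log units; within the scatter), so the two hydrogen-bond acceptors of 4-(methylsulfonyl)phenyl bring no change that can be told from the scatter. Against 3-hydroxy-3-methylbut-1-yn-1-yl, the new group gives a 6.4-fold higher number from compound 2 to compound 4 (0.81 log units; beyond the scatter), so a second aromatic ring here again stands clear of that group. The step from methoxy reads an at least 7.3-fold higher number from compound 1 to compound 4 (0.86 log units; beyond the scatter), a floor set by the limit of compound 1: the limit of < 14 mL.min-1.g-1 in this assay, at which 1 of the 4 values shown sits.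

The compounds shown leave open whether the number follows the aromatic ring itself or what it carries, as an unsubstituted phenyl, or a nitrile or an amine at this position, would test. They also give no cause for any of these steps.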